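The source may report more compounds than this note shows. Statements on the series, on what has been measured and on what is new or still open speak of the compounds shown alone.

Compound 1 `CCCOc1ccc(C(=O)Nc2cccc(CC)n2)cc1` carries an ethyl group on the shared core, and in an in vitro assay on HEK-tsA201 cells for antagonist activity at Neuronal acetylcholine receptor; alpha4/beta2 (Homo sapiens), read by fluorescence and calcium flux (a lower number here means a stronger inhibitor, a higher number a weaker inhibitor), compound 1 gives 37600 nM. Compound 2 `CCCOc1ccc(C(=O)Nc2cccc(Nc3ccc(F)cc3)n2)cc1` has a (4-fluorophenyl)amino group in place of that ethyl. In this assay compound 2 reaches only the limit of the assay, > 100000 nM, so no number is known for it. That change is the step of an at least 2.6-fold higher number from compound 1 to compound 2 (0.42 log units; beyond the scatter). Compound 2 sits at the limit of > 100000 nM in this assay, at which 1 of the 2 values shown sits. Compound 3 `CCCOc1ccc(C(=O)Nc2cccc(Nc3ccc(OC)cc3)n2)cc1` differs from compound 2 by methoxy in place of fluoro on an aromatic carbon. Among the measured compounds shown here, no measured step swaps these two groups; the only step known, from compound 1 to compound 2, concerns a different change and leaves compound 2 at the limit of this assay, so it gives no direction for this swap. Compound 3 is therefore expected to stay near that limit, a step of a number no higher from compound 2 to compound 3 (the limit leaves the size open). Compound 3 is estimated at 100000 nM in this assay, between 30000 nM and 300000 nM.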

Compound 3, half-maximal inhibitory concentration: > 100000 nM
Compound 3 was reported as a limit (the forecaster's own chance of this, stated with the estimate: 60%); the middle value sits exactly at the limit.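

Putting a (4-methoxyphenyl)amino group in place of the ethyl gives an at least 2.6-fold higher number from compound 1 to compound 3 (0.42 log units; beyond the scatter) in this assay, so this weakening is now seen with two different para groups on the added aromatic ring, not with the fluoro compound alone. For compound 3, the value of > 100000 nM is a limit of the assay and not a number. The step from fluoro to methoxy cannot be read, so the two groups cannot be ranked, because both compounds stop at the same limit: the limit of > 100000 nM in this assay, at which 2 of the 3 values shown sit.

From the compounds shown here alone, how much weaker than compound 1 these two compounds really are stays open. Also open, going by these compounds, is whether a plain amine or a methyl in place of the ethyl would give a stronger or a weaker inhibitor than compound 1.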